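Replacing an Ester Side Chain with a Cyclopropylpiperazine

The source may hold more compounds than are shown below. What is called first, only, known or untested is meant among the compounds shown, and "the series" means these compounds.

Measured compounds:
- compound 1, `CCOC(=O)CN(C)c1cc(OCc2cc(F)c(Oc3ccc(Cl)c(C(F)(F)F)c3)c(F)c2)nc(=O)n1C` — 9.68 mL/min/kg
- compound 2, `Cn1c(N2CCCCC2)cc(OCc2cc(F)c(Oc3ccc(Cl)c(C(F)(F)F)c3)c(F)c2)nc1=O` — 5.69 mL/min/kg
- compound 3, `CN1CCN(c2cc(OCc3cc(F)c(Oc4ccc(Cl)c(C(F)(F)F)c4)c(F)c3)nc(=O)n2C)CC1` — 65.5 mL/min/kg

All three were tested in an ADME assay on S9 fraction from liver (Homo sapiens) for metabolic stability, tested at 0.1 uM; a higher number here means faster removal of the compound, a lower number slower removal. Compound 1 stands second highest of the three numbers; its nearest neighbour is compound 2, a step of a 1.7-fold lower number from compound 1 to compound 2 (0.23 log units; within the scatter), which lies within the scatter, and its furthest is compound 3, a step of a 6.8-fold higher number from compound 1 to compound 3 (0.83 log units; beyond the scatter), which lies beyond it.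

Compound 4, `Cn1c(N2CCN(C3CC3)CC2)cc(OCc2cc(F)c(Oc3ccc(Cl)c(C(F)(F)F)c3)c(F)c2)nc1=O`, has not yet been measured in this assay. Relative to compound 1 its change is 4-cyclopropylpiperazin-1-yl in place of ((ethoxycarbonyl)methyl)(methyl)amino on an aromatic carbon. The closest measured guide is the step from compound 1 to compound 3, a 6.8-fold higher number from compound 1 to compound 3 (0.83 log units; beyond the scatter), where a 4-methylpiperazin-1-yl likewise enters in place of the ester-bearing amino group; the step of a 12-fold higher number from compound 2 to compound 3 (1.06 log units; beyond the scatter) points the same way. A rise beyond the scatter in this assay is therefore expected for compound 4, tempered slightly since the cyclopropyl group, not a methyl group, now sits on the piperazine. The estimate for compound 4 is 40 mL/min/kg, within 15 mL/min/kg to 100 mL/min/kg, an expected step of a 4.1-fold higher number from compound 1 to compound 4 (0.62 log units; beyond the scatter).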

Compound 4, clearance: 3.26 mL/min/kg
The estimate for compound 4 lay 12-fold (1.09 log units) above the measured number, outside the stated range (below it).
By their numbers in this assay, from the lowest: compounds 4, 2 and 1 (each within the scatter of the next, the first and the last beyond it); then compound 3.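

In this assay, a piperazine at this position does not by itself bring fast removal: with cyclopropyl in place of methyl on the ring amine nitrogen, the result is a 20-fold lower number from compound 3 to compound 4 (1.30 log units; beyond the scatter), so the group on that nitrogen carries a large part of the outcome. Set against the ester side chain, the 4-cyclopropylpiperazin-1-yl group gives a 3.0-fold lower number from compound 1 to compound 4 (0.47 log units; beyond the scatter), while against piperidin-1-yl it gives a 1.7-fold lower number from compound 2 to compound 4 (0.24 log units; within the scatter), which places these two ring groups level within the scatter. Nothing measured here explains why such a small swap on the piperazine has so large an effect.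

On these data alone, it remains open whether the low number is specific to the three-membered ring or would also appear with an ethyl or isopropyl group on that nitrogen. A piperazine with a free amine hydrogen there would show how the ring behaves with no carbon group at all.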